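Removing One Trifluoromethyl Group from the Sulfonamide with the Highest Number

The source may hold more compounds than are shown below. What is called first, only, known or untested is meant among the compounds shown, and "the series" means these compounds.

The three measured compounds share one core and differ only in the group attached to the sulfonamide nitrogen. Compound 1 `O=C1CCCCC1S(=O)(=O)Nc1cc(C(F)(F)F)ccc1C(F)(F)F` gives 68.6% in a functional assay on KB cells (Homo sapiens) for antiproliferative activity, read by sulforhodamine B assay, tested at 100 ug/mL; a lower number here means less inhibition, a higher number more inhibition at the concentration tested (going by the name of the read-out). Compound 2 `O=C1CCCCC1S(=O)(=O)N1CCOCC1`, in which a saturated ring replaces the aromatic amine, gives -4.35% in this assay, a number that amounts to no inhibition. Compound 3 `O=C1CCCCC1S(=O)(=O)Nc1ccc(Cl)c(Cl)c1`, with a dichlorinated aromatic ring, gives 17.8% in this assay. Among these three numbers compound 1 stands highest, and its distance to compound 3 as well as to compound 2 lies beyond the usual scatter of such measurements, so compound 1 gives the highest inhibition in this assay of the three.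

Compound 4 `O=C1CCCCC1S(=O)(=O)Nc1cccc(C(F)(F)F)c1` is not yet measured. It differs from compound 1 in one place: hydrogen in place of trifluoromethyl on an aromatic carbon. Among the measured compounds shown here, no measured pair in this set shows the effect of taking away a single trifluoromethyl group, so the size of the step has to be judged from compound 1 alone together with the much lower number of compound 3. A decrease beyond the scatter is expected. The estimated step is a number 30.6 percentage points lower from compound 1 to compound 4 (beyond the scatter). With this expected step compound 4 would stand between the numbers of compound 1 and of compound 3. Compound 4 is therefore expected to give about 38% in this assay, within a range from 10% to 65%.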

Compound 4, a percentage reported as inhibition, at one concentration (the size of the read-out at that concentration, not a potency): -6.3%
Beside the measured number, compound 4's estimate is 44.3 percentage points above it; measured number outside the range, below it.
By their numbers in this assay, from the lowest: compounds 4 and 2 (each within the scatter of the next); then compound 3; then compound 1.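

In this assay, hydrogen in place of trifluoromethyl on an aromatic carbon, ortho to a large group and para to a trifluoromethyl group, gives a number 74.9 percentage points lower from compound 1 to compound 4 (beyond the scatter). This pair shows that the inhibition seen with compound 1 at the tested concentration is lost with this one change: compound 4 still carries the other trifluoromethyl group, yet gives -6.3%, a number that amounts to no inhibition, so that remaining group alone does not keep the number up in this series. Nothing measured here accounts for the size of the step, and the reason for it remains unknown.

The compounds shown leave open whether a chlorine atom, a methyl group or a methoxy group on the same aromatic carbon would keep the number of compound 1, and so whether the result is specific to trifluoromethyl or would hold for other groups at that place. Among the compounds shown here, also open is what the other trifluoromethyl group contributes, as no pair here shows its removal while the first one stays in place.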